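Replacing 1H-imidazol-1-yl in compound 3

The compounds below may be only part of what the source reports. "The series", "measured", "known", "first", "only" and "open" are said of these compounds alone.

In an ADME assay on a cell-free system (plasma, Rattus norvegicus) for protein binding, compound 1 `O=C(O)c1cn(Cc2ccc(-n3cccn3)cc2)c2cccc(F)c2c1=O` gives 88.4%, compound 2 `Cc1ccn(-c2ccc(Cn3cc(C(=O)O)c(=O)c4c(F)cccc43)cc2)n1` gives 94.3% and compound 3 `O=C(O)c1cn(Cc2ccc(-n3ccnc3)cc2)c2cccc(F)c2c1=O` gives 83.8%. The two measured steps into compound 3 are a 1.4-fold higher unbound fraction from compound 1 to compound 3 (0.15 log units; within the scatter) and a 2.8-fold higher unbound fraction from compound 2 to compound 3 (0.45 log units; beyond the scatter). Compound 3 therefore stands level with compound 1 and apart from compound 2.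

Compound 4 `O=C(O)c1cn(Cc2ccc(-n3ccc4ncccc43)cc2)c2cccc(F)c2c1=O` differs from compound 3 on an aromatic carbon, para to a large group: a group of 9 heavy atoms (7 carbon, 2 nitrogen; one five-membered aromatic ring with 1 hetero atom, one six-membered aromatic ring with 1 hetero atom) in place of a group of 5 heavy atoms (3 carbon, 2 nitrogen; one five-membered aromatic ring with 2 hetero atoms), on an aromatic carbon. Within the data shown here, no measured step covers a change of this size. The swap of one five-membered group for another gave a 1.4-fold higher unbound fraction from compound 1 to compound 3 (0.15 log units; within the scatter), while the one measured addition to the group at this place, a methyl in place of hydrogen, gave a 2.0-fold lower unbound fraction from compound 1 to compound 2 (0.31 log units; beyond the scatter). That single addition is the nearest guide, so a modest move towards a lower unbound fraction in this assay is expected, with wide uncertainty. The expected step is a 2.3-fold lower unbound fraction from compound 3 to compound 4 (0.36 log units; beyond the scatter). Compound 4 is estimated at 93%, with an expected range of 86% to 97.5%.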

Compound 4, plasma protein binding: 93%
Beside the measured number, compound 4's estimate shows no gap at the digits printed; low and high end bracket the measured number.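

In this assay, among these compounds, this position had so far carried only single five-membered aromatic rings, and the group with one five-membered and one six-membered aromatic ring now gives a 2.3-fold lower unbound fraction from compound 3 to compound 4 (0.36 log units; beyond the scatter) as its step against the imidazole. The same group does not separate from the two pyrazole groups: a 1.2-fold higher unbound fraction from compound 2 to compound 4 (0.09 log units; within the scatter) and a 1.7-fold lower unbound fraction from compound 1 to compound 4 (0.22 log units; within the scatter) are both read as no clear change. Among these compounds, then, the larger group parts only from compound 3, and the read-out does not follow group size alone, with no data on hand to account for these steps.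

Going by these compounds, whether a morpholine or a simple amine at this place would give a higher unbound fraction than compound 3 remains open. Also open, on these data alone, is how indol-1-yl, with carbon only in its six-membered ring, would compare with compound 4.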